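From cyclohexyl to 2-ethoxyphenyl on the shared core

The source may report more compounds than this note shows. Statements on the series, on what has been measured and on what is new or still open speak of the compounds shown alone.

Measured in a functional assay on MCF7 cells (Homo sapiens) for inhibition, read by sulforhodamine B assay; a lower number here means a stronger inhibitor, a higher number a weaker inhibitor:
Compound 1 `O=C1C(Nc2ccc(Br)cc2)=CC(=O)c2c1nc1n2[C@H]2OC[C@@H](O)[C@H]2OC1`: 4330 nM
Compound 2 `O=C1C(NCc2ccccc2)=CC(=O)c2c1nc1n2[C@H]2OC[C@@H](O)[C@H]2OC1`: > 8000 nM
Compound 3 `O=C1C(NC2CCCCC2)=CC(=O)c2c1nc1n2[C@H]2OC[C@@H](O)[C@H]2OC1`: > 16000 nM

Compound 3 stands at a limit, > 16000 nM. Compound 2 also gives only a limit, > 8000 nM. Compound 4 `CCOc1ccccc1NC1=CC(=O)c2c(nc3n2[C@H]2OC[C@@H](O)[C@H]2OC3)C1=O` carries 2-ethoxyphenyl in place of cyclohexyl on an amine nitrogen. The closest measured change is an at least 3.6-fold higher number from compound 1 to compound 3 (0.56 log units; beyond the scatter), where 4-bromophenyl gives way to cyclohexyl. The new change runs the opposite way, from cyclohexyl back to a substituted phenyl. The smaller at least 1.8-fold higher number from compound 1 to compound 2 (0.26 log units; that floor lies within the scatter) points the same way, and a step that the two limits leave unreadable from compound 2 to compound 3 adds nothing. A modest fall in this assay is therefore expected, and the estimated step is an at least 2.6-fold lower number from compound 3 to compound 4 (0.42 log units; beyond the scatter). For compound 4 the estimate is 6000 nM, with an expected range of 2500 nM to 16000 nM.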

Compound 4, half-maximal inhibitory concentration: > 4000 nM
Compound 4: only a limit was reported; the forecaster's own chance of this, stated with the estimate: 30%; the middle value is on the limit's open side.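

In this assay compound 4 gives only a limit, > 4000 nM. Among the compounds shown here, no step from compound 4 to compound 1, compound 2 or compound 3 can be read. The compounds shown leave open how 2-ethoxyphenyl compares with cyclohexyl, benzyl or 4-bromophenyl on the shared core.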